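Extending the Carbamoyl Substituent: From Compound 2 to Compound 3

The compounds below may be only part of what the source reports. "The series", "measured", "known", "first", "only" and "open" are said of these compounds alone.

Measured compounds:
- compound 1, `C/N=C(/S)C1=CC(CF)(CF)Oc2ccc([N+](=O)[O-])cc21`, with 74.5%
- compound 2, `CNC(=O)C1=CC(CF)(CF)Oc2ccc([N+](=O)[O-])cc21`, with 70.7%

In a functional assay on the whole organism (aorta) with Rattus norvegicus as the target (a higher number here means a larger maximal response, a lower number a smaller maximal response), compound 2 gives 70.7%, the lower of the two numbers in hand, and compound 1 gives 74.5%; the two lie within the scatter of each other, so no order between them can be read. Among the compounds with values here, the one measured step, a number 3.8 percentage points lower from compound 1 to compound 2 (within the scatter), concerns the exchange of the thioamide-type group for the amide-type group on the core and says nothing about what hangs on the amide nitrogen.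

Compound 3, `N#CCCNC(=O)C1=CC(CF)(CF)Oc2ccc([N+](=O)[O-])cc21`, differs from compound 2 by cyanomethyl in place of hydrogen on a saturated chain carbon bound to an amide-type nitrogen. Within the data shown here, no measured pair touches this part of the molecule, so there is no step to lean on; the only information is that the one alteration seen so far, on the same side chain, stayed within the scatter in this assay. The expectation for compound 3 is therefore a step of a number 0.7 percentage points lower from compound 2 to compound 3 (within the scatter), that is, none beyond the scatter. Compound 3 is estimated at 70%, within a range from 52% to 86%.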

Compound 3, intrinsic activity: the largest response reached, in percent of the reference agonist's: 72.3%
Estimate against measurement, compound 3: 2.3 percentage points below; the range from low to high includes it.
By their numbers in this assay, from the lowest: compounds 2, 3 and 1 (each within the scatter of the next).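

In this assay, within the data shown here, cyanomethyl in place of hydrogen on a saturated chain carbon bound to an amide-type nitrogen gives a number 1.6 percentage points higher from compound 2 to compound 3 (within the scatter), the first reading at this position, so going from methylcarbamoyl to (2-cyanoethyl)carbamoyl brings no shift in maximal response that can be told from the scatter. Exchanging the whole group on the double-bonded ring carbon, a group of the kind carried by compound 1 for the larger one carried by compound 3, likewise gives a number 2.2 percentage points lower from compound 1 to compound 3 (within the scatter), which means that the thioamide-type group and the extended amide-type group cannot be told apart in this read-out either. Nothing measured here offers a reason for this outcome.

With all the compounds shown lying within the scatter of one another, it remains open whether any change at this position can move the maximal response at all. A carboxylic acid, an amine or a longer chain in place of cyanomethyl would test this, and whether such a group would stay within the scatter or leave it cannot be said from these compounds.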